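The source may hold more compounds than are shown below. What is called first, only, known or untested is meant among the compounds shown, and "the series" means these compounds.

Measured so far:
compound 1 `Nc1nc(N)c2c(-c3ccsc3)cn([C@@H]3O[C@H](CO)[C@@H](O)[C@H]3O)c2n1`, > 20000 nM
compound 2 `Cc1ncnc2c1c(I)cn2[C@@H]1O[C@H](CO)[C@@H](O)[C@H]1O`, 17800 nM
compound 3 `Cc1nc(N)c2c(-c3ccccc3)cn([C@@H]3O[C@H](CO)[C@@H](O)[C@H]3O)c2n1`, > 20000 nM

Of the compounds shown here, three that share a core have been tested in a functional assay on K562 cells (Homo sapiens), read by MTT assay, with a stated time of 72 h; on this read-out lower numbers stand for stronger inhibition and higher numbers for weaker inhibition. Compound 1 `Nc1nc(N)c2c(-c3ccsc3)cn([C@@H]3O[C@H](CO)[C@@H](O)[C@H]3O)c2n1` reaches only the limit of the assay, > 20000 nM, and no number is known for it. Compound 3 `Cc1nc(N)c2c(-c3ccccc3)cn([C@@H]3O[C@H](CO)[C@@H](O)[C@H]3O)c2n1` likewise sits at the limit, > 20000 nM. Going by the values given here, compound 2 `Cc1ncnc2c1c(I)cn2[C@@H]1O[C@H](CO)[C@@H](O)[C@H]1O` is the one compound with a measured number: in this assay compound 2 gives 17800 nM. It therefore stands as the only figure among the three, with the other two at the limit (the limit of > 20000 nM in this assay, at which 2 of the 3 values shown sit).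

The piece now turns to compound 4 `Cc1ncnc2c1c(-c1cccs1)cn2[C@@H]1O[C@H](CO)[C@@H](O)[C@H]1O`, which has not yet been measured in this assay. Compound 4 differs from compound 2 in one place: thiophen-2-yl in place of iodo on an aromatic carbon. Among the compounds with values here, no step between two measured compounds matches this change, so nothing in the measured set tells the size or direction of the effect. The step from compound 2 to compound 4 is expected to be small or, more likely, toward weaker inhibition, as a 1.1-fold higher number from compound 2 to compound 4 (0.05 log units; within the scatter). Compound 4 is estimated at 20000 nM, between 6000 nM and 60000 nM, with a good chance that the assay reports only a limit.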

Compound 4, half-maximal inhibitory concentration: > 20000 nM
Compound 4: a limit, no number; the forecaster's own chance of this, stated with the estimate: 55%; the middle value lies on the limit itself.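

Read in this assay, the change from iodo to thiophen-2-yl on this aromatic carbon gives an at least 1.1-fold higher number from compound 2 to compound 4 (0.05 log units; that floor lies within the scatter). Going by these compounds alone, it is the first step in the set that can be read at this position, and it shows that an aromatic ring with a sulfur atom in place of the iodine brings no measured gain in inhibition in these cells. Compound 4 is itself only a limit, and it joins the other compounds there, so the step is a floor and its true size stays unknown: the limit of > 20000 nM in this assay, at which 3 of the 4 values shown sit.

The compounds shown leave open how far compound 4 lies from compound 2, and whether any group on this carbon can give a clearly lower number than iodo does on the shared core. An amine, a methoxy group or a short alkyl chain in this place would test that, since each would replace the iodo with something other than an aromatic ring and could give a number rather than a limit.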